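A few compounds are considered here, and "the series" means these few. Any claim that something is new, unique, unknown or untested is made for them only; others in the source may bear on it.

Series notes. Compound 1 `CCC(=O)Nc1ccc(S(=O)(=O)Oc2ccccc2C(C)C)cc1` carries a propanoylamino group and an isopropyl group on an aromatic carbon; in a functional assay on MCF7 cells (Homo sapiens) for antiproliferative activity, read by sulforhodamine B assay, with a stated time of 48 h (on this read-out lower numbers stand for stronger inhibition and higher numbers for weaker inhibition), compound 1 gives 11000 nM. Compound 2 `CCC(=O)Nc1ccc(S(=O)(=O)Oc2ccccc2I)cc1` gives 8100 nM, and the exchange of iodo in place of isopropyl on an aromatic carbon, a 1.4-fold lower number from compound 1 to compound 2 (0.13 log units; within the scatter), keeps the two within the scatter of each other. Compound 3 `CCNC(=O)Nc1ccc(S(=O)(=O)Oc2ccccc2I)cc1` gives 1100 nM; the gap from compound 1 to compound 3 is beyond the scatter, so compound 1 sits at the weak end of the three numbers. The step ethylamino in place of ethyl on a carbonyl carbon, a 7.4-fold lower number from compound 2 to compound 3 (0.87 log units; beyond the scatter), is the only move in the set that goes beyond the scatter.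

Compound 4 `CCCCCNC(=O)Nc1ccc(S(=O)(=O)Oc2ccccc2C(C)C)cc1` is not yet measured. It differs from compound 1 in one place: pentylamino in place of ethyl on a carbonyl carbon. Among the compounds with values here, this is the same kind of exchange at the carbonyl carbon as seen from compound 2 to compound 3, with a pentylamino group where compound 3 has ethylamino; no measured pair shows what the longer chain does on its own, so that part remains open. The expectation rests on compound 3, whose step a 7.4-fold lower number from compound 2 to compound 3 (0.87 log units; beyond the scatter) was modest but clear. For compound 4 a step of about a 7.3-fold lower number from compound 1 to compound 4 (0.87 log units; beyond the scatter) is therefore expected. Compound 4 is estimated at 1500 nM, with a range of 500 nM to 5000 nM.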

Compound 4, half-maximal inhibitory concentration: 4000 nM
Estimate against measurement, compound 4: 2.7-fold (0.43 log units) below; low and high end bracket the measured number.
By their numbers in this assay, from the lowest: compound 3; then compound 4; then compounds 2 and 1 (each within the scatter of the next).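

In this assay the exchange of ethyl for pentylamino on a carbonyl carbon gives a 2.8-fold lower number from compound 1 to compound 4 (0.44 log units; beyond the scatter) with the isopropyl group kept in place, so a lower number from this kind of exchange is no longer tied to the iodo compounds or to the ethylamino group. Set beside a 7.4-fold lower number from compound 2 to compound 3 (0.87 log units; beyond the scatter), it points the same way, and in both pairs an alkylamino group in place of ethyl on the carbonyl carbon lowers the number beyond the scatter, with neither pair going against this. Nothing at hand bears on what lies behind this step.

Going by these compounds, how much of the difference between the two steps belongs to the chain and how much to the aromatic group remains open, since they differ in both places; pentylamino on the iodo compound, or ethylamino on the isopropyl compound, would separate the two. Also open, on these data alone, is how far the trend runs along the chain, for instance with a longer chain such as octylamino, with a cyclohexylamino group, or with a chain ending in a carboxylic acid or an amine.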